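Methoxy addition to compound 1: expected step

The source may hold more compounds than are shown below. What is called first, only, known or untested is meant among the compounds shown, and "the series" means these compounds.

In a functional assay on DU-145 cells (Homo sapiens) for cytotoxicity, read by trypan blue exclusion, with a stated time of 96 h (on this read-out lower numbers stand for stronger inhibition and higher numbers for weaker inhibition), compound 1 `COc1ccc(CS(=O)(=O)/C=C/c2ccccc2OC)cc1N` gives 7500 nM, the highest of the three numbers measured. Compound 2 `COc1ccc(/C=C/S(=O)(=O)Cc2ccc(OC)c(N)c2)c(OC)c1` gives 500 nM, and compound 3 `COc1ccc(OC)c(/C=C/S(=O)(=O)Cc2ccc(OC)c(N)c2)c1` gives 750 nM. Compound 4 `COc1ccc(CS(=O)(=O)/C=C/c2c(OC)cccc2OC)cc1N` is still unmeasured. It differs from compound 1 by methoxy in place of hydrogen on an aromatic carbon, ortho to a large group and meta to a methoxy group. The same kind of change gave a 15-fold lower number from compound 1 to compound 2 (1.18 log units; beyond the scatter) and a 10-fold lower number from compound 1 to compound 3 (1.00 log units; beyond the scatter), both beyond the scatter. Going by the values given here, no measured compound has a methoxy at this place, so a similar step towards a lower number in this assay is expected only with wide uncertainty. The estimated step is a 9.4-fold lower number from compound 1 to compound 4 (0.97 log units; beyond the scatter). The estimate for compound 4 is 800 nM, with an expected range of 250 nM to 3000 nM.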

Compound 4, half-maximal inhibitory concentration: 50 nM
Beside the measured number, compound 4's estimate is 16-fold (1.20 log units) above it, outside the stated range (below it).
By their numbers in this assay, from the lowest: compound 4; then compounds 2 and 3 (each within the scatter of the next); then compound 1.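

a 150-fold lower number from compound 1 to compound 4 (2.18 log units; beyond the scatter) in this assay marks the place ortho to a large group and meta to a methoxy group as highly responsive to methoxy in place of hydrogen. The same kind of change gave smaller steps elsewhere on the ring: a 15-fold lower number from compound 1 to compound 2 (1.18 log units; beyond the scatter) and a 10-fold lower number from compound 1 to compound 3 (1.00 log units; beyond the scatter). No available evidence explains this larger step.

Hydrogen and methoxy are the only groups shown at this place, so the response to ethoxy, hydroxyl or chlorine there remains open. Going by these compounds, whether the step depends on the other methoxy group also remains open.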